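Methoxy in place of hydrogen on a thiochromenone-type scaffold

The compounds below may be only part of what the source reports. "The series", "measured", "known", "first", "only" and "open" are said of these compounds alone.

Compound 1, `S=c1cc(-c2ccccc2)oc2ccccc12`: "not active" (no number reported)
Compound 2, `Fc1ccc2c(=S)cc(-c3ccccc3)oc2c1`: 40%

In an in vitro assay on BTI-TN-5B1-4 cells for inhibition of Amine oxidase [flavin-containing] A (Homo sapiens), tested at 100 uM (a lower number here means less inhibition, a higher number more inhibition at the concentration tested (going by the name of the read-out)), compound 1 was reported as "not active" (no number reported), with no number given. For the measured compounds named here, compound 2 is the only compound here with a number, giving 40% in this assay. Compound 3, `COc1ccc(-c2cc(=S)c3ccc(F)cc3o2)cc1`, has not been measured. It differs from compound 2 by methoxy in place of hydrogen on an aromatic carbon. Nothing measured here shows what this change does, so a step near the scatter, in no set direction, is expected for no change at the digits printed from compound 2 to compound 3 (within the scatter). Compound 3 is therefore estimated at 40% in this assay, between 15% and 65%.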

Compound 3, a percentage reported as inhibition, at one concentration (the size of the read-out at that concentration, not a potency): "not active" (no number reported)
Compound 3 has no reported number here; the estimate stays without a comparison.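

In this assay, for the compounds shown here, compound 3 gives "not active" (no number reported), so no step from compound 2 can be read. The compounds shown leave open what methoxy in place of hydrogen does to inhibition, and no evidence here bears on this result.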